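Swapping tert-butyl for methylamino on the carbonyl

The source may hold more compounds than are shown below. What is called first, only, known or untested is meant among the compounds shown, and "the series" means these compounds.

In an assay on HEK-293T cells for inhibition of diacylglycerol lipase-alpha (Homo sapiens), read by colorimetric assay (on this read-out lower numbers stand for stronger inhibition and higher numbers for weaker inhibition), compound 1 `O=C(CCCCCCc1ccccc1)c1nnc(-c2ccccc2)[nH]1` returns only a limit, > 10000 nM. Compound 2 `O=C(CCCCCCc1ccccc1)c1nnn(-c2ccco2)n1` likewise reaches only a limit in this assay, > 10000 nM. Compound 3 `CC(C)(C)C(=O)c1coc(C(=O)CCCCCCc2ccccc2)n1` is the one compound that yields a number in this assay, 479 nM, so it stands alone among the shown results, with the two others sitting at the limit of > 10000 nM in this assay, at which 2 of the 3 values shown sit. Compound 4 `CNC(=O)c1coc(C(=O)CCCCCCc2ccccc2)n1` differs from compound 3 in a single place: methylamino in place of tert-butyl on a carbonyl carbon, which one bond further out reads as (tert-butyl)carbonyl to methylcarbamoyl. For the measured compounds named here, no measured pair traces this step. The step from compound 3 to compound 4 is expected to be a modest weakening, somewhat beyond the scatter, a 3.1-fold higher number from compound 3 to compound 4 (0.50 log units; beyond the scatter). Compound 4 is therefore estimated at 1500 nM, in a range from 400 nM to 6000 nM.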

Compound 4, half-maximal inhibitory concentration: > 10000 nM
Compound 4 was reported as a limit; the forecaster's own chance of this, stated with the estimate: 15%; middle value at least 6.6-fold (0.82 log units) from the limit.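

On a carbonyl carbon whose other neighbour is an aromatic carbon, the group matters: methylamino in place of tert-butyl gives an at least 20-fold higher number from compound 3 to compound 4 (1.31 log units; beyond the scatter) in this assay. From the compounds shown here alone, the size of this step is itself bounded, since compound 4 gives only a limit, so how far the inhibition falls stays unknown. Compound 3 remains the only compound with a number: the limit of > 10000 nM in this assay, at which 3 of the 4 values shown sit.

Going by these compounds, whether the fall follows from losing tert-butyl or from gaining the amide hydrogen stays open. Dimethylamino or isopropyl on the same carbonyl would separate the two.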